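This account rests on a few compounds, and the source may have more. Where it says the series, first, only, none or still open, it means among the compounds named here.

Compound 1 `ClCc1ccccc1Cn1cnc2c(Cl)nc(Cl)nc21` — 30 nM
Compound 2 `ClCc1ccccc1Cn1cnc2ncnc(Cl)c21` — 1440 nM
Compound 3 `ClCc1ccc(Cn2cnc3c(Cl)nc(Cl)nc32)cc1` — 1950 nM

Of the compounds shown here, three have so far been tested in a functional assay on CCRF-CEM cells (Homo sapiens) for cytotoxicity, read by sulforhodamine B assay, with a stated time of 48 h; on this read-out higher numbers stand for weaker inhibition of growth and lower numbers for stronger inhibition of growth. Compound 1 gives 30 nM in this assay, the lowest of the three numbers. Compound 2 gives 1440 nM, the nearest number to compound 1 yet beyond the scatter of repeated measurements. Compound 3 gives 1950 nM, the furthest from compound 1 and also beyond the scatter. Neither of these two differs from compound 1 in only one place, so no single step can be read from them.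

Compound 4 `Nc1nc(Cl)c2ncn(Cc3ccccc3CCl)c2n1` has not yet been measured in this assay. It differs from compound 1 by amino in place of chloro on an aromatic carbon of the shared core. Within the data shown here, no measured pair shows this exchange, so its effect cannot be read from the compounds in hand; the account therefore rests on compound 1 alone, which is the strongest starting point available because it gives 30 nM. The step of a 5.0-fold higher number from compound 1 to compound 4 (0.70 log units; beyond the scatter) is expected to be a moderate move toward weaker growth inhibition, though a step within the scatter cannot be excluded. Compound 4 is accordingly estimated at 150 nM, with a range from 30 nM to 800 nM.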

Compound 4, concentration for 50% growth inhibition: 17800 nM
For compound 4 the middle estimate is 120-fold (2.07 log units) below the measured one; the whole stated range lies below it.
By their numbers in this assay, from the lowest: compound 1; then compounds 2 and 3 (each within the scatter of the next); then compound 4.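

In this assay the exchange of chloro for amino gives a 590-fold higher number from compound 1 to compound 4 (2.77 log units; beyond the scatter) and so is a large move toward weaker growth inhibition. This is the only pair shown that differs in one place, and it gives the first direct reading at this aromatic carbon between two ring nitrogen atoms: chloro there cannot be replaced by amino without a heavy cost in this cell assay, even though the change swaps just one heavy atom for another and adds one hydrogen-bond donor and one hydrogen-bond acceptor. No measurement offered here accounts for the size of this step.

The compounds shown leave open whether the loss comes from the arrival of amino or from the departure of chloro, a question that a hydrogen, a fluoro, a methoxy or a methylamino group at the same carbon would help to separate. They also leave open whether amino in place of the other chloro group, which stands meta to this position, would cost as much, and whether the same exchange would carry the same cost with the chloromethyl group elsewhere on the benzyl ring.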